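Swapping the aryl group on an oxazole-linked piperidine amide

The compounds below may be only part of what the source reports. "The series", "measured", "known", "first", "only" and "open" are said of these compounds alone.

Measured compounds:
- compound 1, `Cc1oc(-c2c(C)c(C)c(C)c(C)c2C)nc1CN1CCC(C(=O)NCCCN2C[C@H](C)C[C@H](C)C2)CC1`: 8180 nM
- compound 2, `Cc1ccccc1-c1nc(CN2CCC(C(=O)NCCCCN3C[C@H](C)C[C@H](C)C3)CC2)c(C)o1`: 23100 nM
- compound 3, `Cc1cccc(Cl)c1-c1nc(CN2CCC(C(=O)NCCCN3CCC(C(C)C)CC3)CC2)c(C)o1`: 4910 nM

These three compounds share a core and were tested in an ADME assay on Huh7.5.1 cells (Homo sapiens) for cytotoxicity, read by ATP content, with a stated time of 48 h; a lower number here means that less compound is tolerated, a higher number that more compound is tolerated. Compound 1 gives 8180 nM in this assay, the second highest of the three numbers. Compound 3 lies closest to it, and the gap between the two falls within the usual scatter, so nothing can be read into it. Compound 2 is the furthest away, with a higher number that does lie beyond the scatter.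

Compound 4, `COc1ccc(-c2nc(CN3CCC(C(=O)NCCCN4C[C@H](C)C[C@H](C)C4)CC3)c(C)o2)cc1OC`, has not yet been measured in this assay. It differs from compound 1 in one place: 3,4-dimethoxyphenyl in place of 2,3,4,5,6-pentamethylphenyl on an aromatic carbon. Among the measured compounds shown here, no measured pair in this set shows a step of this kind, so there is no direct guide to its size. The expectation is that the step of a 1.3-fold higher number from compound 1 to compound 4 (0.13 log units; within the scatter) will be small, and quite possibly within the scatter, with a slight lean towards a higher number. On that basis compound 4 is estimated to give about 11000 nM in this assay, somewhere between 4500 nM and 27000 nM.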

Compound 4, half-maximal cytotoxic concentration: 57200 nM
Beside the measured number, compound 4's estimate is 5.2-fold (0.72 log units) below it; the whole stated range lies below it.
By their numbers in this assay, from the lowest: compounds 3 and 1 (each within the scatter of the next); then compound 2; then compound 4.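

In this assay, the aryl group on the shared core proves to be a position that matters: 3,4-dimethoxyphenyl in place of 2,3,4,5,6-pentamethylphenyl gives a 7.0-fold higher number from compound 1 to compound 4 (0.84 log units; beyond the scatter). Among the compounds shown here, the earlier compounds differ from one another in more than one place, so this is the first step in the set that ties a change beyond the scatter to this aryl group alone. The swap replaces a group of carbon only with one carrying methoxy groups that count as hydrogen-bond acceptors, but no measurement here links the step to that difference or to any other cause.

With a single replacement shown, it remains open whether the higher number follows from losing the methyl groups, gaining the methoxy groups, or both. An unsubstituted phenyl or a phenyl with one methoxy group at this position would help separate these possibilities.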